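This account rests on a few compounds, and the source may have more. Where it says the series, first, only, none or still open, it means among the compounds named here.

Compound 2 `CCCC(Oc1ccc(-n2cc3ccccc3n2)cc1)c1ccc(C(=O)NCCC(=O)O)cc1` gives the lowest number of the three measured compounds in an assay on cells for displacement of a labelled ligand from Glucagon receptor (Homo sapiens), in the presence of a further agent that is not named here (on this read-out higher numbers stand for weaker inhibition and lower numbers for stronger inhibition), at 290 nM. Compound 3 `O=C(O)CCNC(=O)c1ccc(C(Oc2ccc(-n3cc(C(F)(F)F)cn3)cc2)C2CCC2)cc1` comes nearest with 700 nM, and compound 1 `CCCC(Oc1ccc(-n2cc(OC)cn2)cc1)c1ccc(C(=O)NCCC(=O)O)cc1` lies furthest with 4400 nM. Compound 4 `CCCC(Oc1ccc(-n2cc(C(F)(F)F)cn2)cc1)c1ccc(C(=O)NCCC(=O)O)cc1` has not been measured. It differs from compound 2 in one place: 4-(trifluoromethyl)-1H-pyrazol-1-yl in place of 2H-indazol-2-yl on an aromatic carbon. Among the compounds with values here, the one measured step that bears on this is a 15-fold lower number from compound 1 to compound 2 (1.18 log units; beyond the scatter), which shows how much a change of the same aromatic group can move this assay. Compound 3 carries the same 4-(trifluoromethyl)-1H-pyrazol-1-yl group and shows 700 nM. Compound 4 is therefore expected to give a higher number than compound 2, with an estimated step of a 3.1-fold higher number from compound 2 to compound 4 (0.49 log units; beyond the scatter). The estimate for compound 4 is 900 nM, expected to fall between 350 nM and 2500 nM.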

Compound 4, inhibition constant: 890 nM
Compound 4: middle estimate off by 1.0-fold (0.00 log units), on the high side, and the stated range covers the measured number.
By their numbers in this assay, from the lowest: compound 2; then compounds 3 and 4 (each within the scatter of the next); then compound 1.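

In this assay, 4-(trifluoromethyl)-1H-pyrazol-1-yl in place of 2H-indazol-2-yl gives a 3.1-fold higher number from compound 2 to compound 4 (0.49 log units; beyond the scatter), so the two-ring group keeps the lowest number of this set. Within the pyrazole series, trifluoromethyl in place of methoxy gives a 4.9-fold lower number from compound 1 to compound 4 (0.69 log units; beyond the scatter), showing that the single group on this ring matters by itself. Propyl in place of cyclobutyl gives a 1.3-fold higher number from compound 3 to compound 4 (0.10 log units; within the scatter), so that swap has no readable effect here.

Nothing shown explains these differences. Also open, going by these compounds, is how a nitrile or a chlorine atom in place of trifluoromethyl would read.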